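A few compounds are considered here, and "the series" means these few. Any claim that something is new, unique, unknown or untested is made for them only; others in the source may bear on it.

Values in a physicochemical assay for lipophilicity, read by spectrophotometry, using the shake flask method, in phosphate buffer, measured as octanol-water partition, with a stated time of 4 h, at pH 7.4 (a lower number here means a more polar compound, a higher number a more lipophilic compound), for three compounds:
Compound 1 `COc1ccc(Cn2nnc(O)c2C(=O)Nc2cccc(C(F)(F)F)c2)cc1` gives 1.1
Compound 2 `COc1ccc(Cn2nnc(O)c2C(=O)Nc2cccc(-c3ccc(O)cc3)c2)cc1` gives 2.19
Compound 3 `COc1ccc(Cn2nnc(O)c2C(=O)Nc2cccc(-c3ccc(OC)cc3)c2)cc1` gives 2.59

Compound 3 has the highest of these numbers, and both gaps to it lie beyond the scatter. Compound 4 `COc1ccc(Cn2nnc(O)c2C(=O)Nc2cccc(-c3cccc(OC)c3)c2)cc1` differs from compound 3 by 3-methoxyphenyl in place of 4-methoxyphenyl on an aromatic carbon and carries 3-methoxyphenyl in place of 4-methoxyphenyl on an aromatic carbon. For the measured compounds named here, no measured step moves a methoxy group in this way. The nearest evidence is a number 0.40 log units higher from compound 2 to compound 3 (beyond the scatter) as a modest step and a number 1.49 log units higher from compound 1 to compound 3 (beyond the scatter) as a large one, and both of those change the atoms, while here the atoms stay the same. The estimated change is a number 0.01 log units higher from compound 3 to compound 4 (within the scatter) and is not expected to pass the scatter. In this assay compound 4 is expected at 2.6 with an estimated range between 2.2 and 3 as the likely span.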

Compound 4, distribution coefficient: 2.5
Compound 4: the middle estimate sits 0.10 log units above what was measured; the measured number falls inside the stated range.
By their numbers in this assay, from the lowest: compound 1; then compound 2; then compounds 4 and 3 (each within the scatter of the next).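

In this assay, for the compounds shown here, shifting the methoxy group from 4-methoxyphenyl to 3-methoxyphenyl, with the same atoms joined differently, gives a number 0.09 log units lower from compound 3 to compound 4 (within the scatter) and is the first change at this position that does not pass the scatter. The 3-methoxyphenyl group still keeps its distance from the other two groups, with a number 1.40 log units higher from compound 1 to compound 4 (beyond the scatter) and a number 0.31 log units higher from compound 2 to compound 4 (beyond the scatter) as the steps. Nothing available accounts for these readings. The compounds shown leave open whether 3-hydroxyphenyl would follow the same course, and how a carboxylic acid or an amine in place of the methoxy group would read.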